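Azetidine-free note: mirror image of compound 2 in cytotoxicity

The compounds below may be only part of what the source reports. "The series", "measured", "known", "first", "only" and "open" are said of these compounds alone.

Values so far in a functional assay on KB cells (Homo sapiens) for cytotoxicity (a higher number here means a weaker inhibitor, a lower number a stronger inhibitor), are these.
- compound 1 `CCCCCCCCCCCCCC[C@@H]1N[C@H](CO)[C@H]1O` gives > 10 ug/mL (a limit)
- compound 2 `CCCCCCCCCCCCCC[C@H]1N[C@@H](CO)[C@H]1O` gives > 10 ug/mL (a limit)

Compound 2 stands only at its limit of > 10 ug/mL in this assay and has no number. Compound 3 `CCCCCCCCCCCCCC[C@@H]1N[C@H](CO)[C@@H]1O` relates to compound 2 as follows: the two compounds have the same atoms and bonds and differ only in configuration as drawn: 3 of 3 stereo elements differ (all stereocentres are inverted: mirror images); a stereocentre at a saturated ring carbon is drawn R in compound 2 and S in compound 3; a stereocentre at a saturated ring carbon is drawn S in compound 2 and R in compound 3; a stereocentre at a saturated ring carbon is drawn S in compound 2 and R in compound 3 (nothing leaves and nothing enters). For the measured compounds named here, the one measured step that bears on this is a step that the two limits leave unreadable from compound 1 to compound 2 and it gives no size to carry over. Going by the values given here, it is still the nearest precedent, resting on the fact that compounds 1 and 2 differ only in the configuration as drawn as a change of configuration alone. The data stop at the limit of > 10 ug/mL in this assay, at which 2 of the 2 values shown sit, and no number shows what configuration does in this series. No step beyond the usual scatter is therefore expected in this assay and no direction is favoured. The expected step is a step that the limit leaves unreadable from compound 2 to compound 3 and it should be read with that open direction in mind. Compound 3 is estimated at 15 ug/mL with an expected range from 6 ug/mL to 40 ug/mL and a report as a limit is the likeliest outcome.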

Compound 3, half-maximal inhibitory concentration: > 10 ug/mL
Compound 3: only a limit was reported; the forecaster's own chance of this, stated with the estimate: 70%; the middle value is on the limit's open side.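

For the compounds shown here, compound 1, compound 2 and compound 3 all sit at a limit in this assay, and no step among them can be read. The compounds shown leave open whether configuration alone alters cytotoxicity in this series, and in which direction, with no number yet to show it: the limit of > 10 ug/mL in this assay, at which 3 of the 3 values shown sit.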